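Swapping the Group on the Sulfonyl Sulfur

A few compounds are considered here, and "the series" means these few. Any claim that something is new, unique, unknown or untested is made for them only; others in the source may bear on it.

Compound 1 `O=S(=O)(Nc1ccc(-c2nc3ccccc3o2)cc1)c1ccc(Cl)s1` gives > 100000 nM as a limit, not a number.
Compound 2 `O=S(=O)(Nc1ccc2oc(-c3ccccc3)nc2c1)c1ccc(Cl)cc1` gives 65000 nM as its value.
Compound 3 `O=S(=O)(Nc1ccc2oc(-c3ccccc3)nc2c1)c1ccc(Cl)c(C(F)(F)F)c1` gives 66000 nM as its value.
Compound 4 `O=S(=O)(Nc1ccc(-c2nc3ccccc3o2)cc1)c1ccccc1F` has not been measured yet.

In an ADME assay on HEK293 cells (Homo sapiens) for cytotoxicity, read by resazurin assay, with a stated time of 48 h (a higher number here means that more compound is tolerated, a lower number that less compound is tolerated), compound 1 stands at > 100000 nM and this is a limit, not a number. The move to compound 4 puts 2-fluorophenyl in place of 5-chlorothiophen-2-yl on a sulfonyl sulfur and leaves the core of compound 1 as it is.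

Within the data shown here, no measured step makes this swap itself. Among the measured compounds shown here, the only measured step is a 1.0-fold higher number from compound 2 to compound 3 (0.01 log units; within the scatter) with trifluoromethyl in place of hydrogen on an aromatic carbon. It involves a different group on a different core, so it is only a loose guide. With a 1.0-fold higher number from compound 2 to compound 3 (0.01 log units; within the scatter) as that guide, no step beyond the scatter is expected in this assay for this swap. The estimated move is an at least 1.1-fold lower number from compound 1 to compound 4 (0.07 log units; that floor lies within the scatter) and it stays rough, since it starts from a limit. For compound 4 the estimate is 85000 nM (expected range 40000 nM to 150000 nM).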

Compound 4, half-maximal cytotoxic concentration: > 100000 nM
Compound 4: no number, only a limit (the forecaster's own chance of this, stated with the estimate: 50%); middle value at least 1.1-fold (0.07 log units) from the limit.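

Among these compounds, compound 1 and compound 4 both end at a limit rather than a number, so no step between them can be read: the limit of > 100000 nM in this assay, at which 2 of the 4 values shown sit. The compounds shown leave open whether 2-fluorophenyl in place of 5-chlorothiophen-2-yl on a sulfonyl sulfur changes the tolerated concentration at all.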